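The source may report more compounds than this note shows. Statements on the series, on what has been measured and on what is new or still open speak of the compounds shown alone.

In a functional assay on SK-MEL-2 cells (Homo sapiens) for cytotoxicity (a lower number here means a stronger inhibitor, a higher number a weaker inhibitor), three compounds sharing one core give closely matched numbers: compound 1 (`Cc1nn(C)c(-n2cccc2)c1/C=N/OCc1ccc(C(=O)OC(C)(C)C)cc1`) gives 24.9 ug/mL, compound 2 (`Cc1nn(C)c(-n2ccc3ccccc32)c1/C=N/OCc1ccc(C(=O)OC(C)(C)C)cc1`) gives 26.5 ug/mL, and compound 3 (`Cc1nn(C)c(-n2cccn2)c1/C=N/OCc1ccc(C(=O)OC(C)(C)C)cc1`) gives 28.8 ug/mL. Compound 3 therefore stands within the scatter of both others. Compound 4 (`Cc1nn(C)c(N(C)C)c1/C=N/OCc1ccc(C(=O)OC(C)(C)C)cc1`) carries dimethylamino in place of 1H-pyrazol-1-yl on an aromatic carbon. The measured exchanges at that place are small: a 1.1-fold higher number from compound 1 to compound 2 (0.03 log units; within the scatter), a 1.2-fold higher number from compound 1 to compound 3 (0.06 log units; within the scatter) and a 1.1-fold higher number from compound 2 to compound 3 (0.04 log units; within the scatter). Each swaps one ring group for another, whereas dimethylamino has no ring, so the data do not cover this change directly. No step beyond the scatter is expected in this assay, and the estimated step is a 1.1-fold lower number from compound 3 to compound 4 (0.03 log units; within the scatter). Compound 4 is estimated at 27 ug/mL, with an expected range from 13 ug/mL to 50 ug/mL.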

Compound 4, half-maximal inhibitory concentration: 23.9 ug/mL
For compound 4 the middle estimate is 1.1-fold (0.05 log units) above the measured one; low and high end bracket the measured number.
By their numbers in this assay, from the lowest: compounds 4, 1, 2 and 3 (each within the scatter of the next).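

Dimethylamino, which has no ring, gives numbers at this aromatic carbon that stay within the scatter of all three ring groups in this assay (a 1.2-fold lower number from compound 3 to compound 4 (0.08 log units; within the scatter)) (a 1.1-fold lower number from compound 2 to compound 4 (0.04 log units; within the scatter)) (a 1.0-fold lower number from compound 1 to compound 4 (0.02 log units; within the scatter)). The flat picture seen among ring groups therefore extends to a group without a ring, a change the ring-for-ring exchanges did not cover. No evidence is available that explains this result. From the compounds shown here alone, whether a primary amine, a carboxylic acid or a longer chain on this aromatic carbon would move the number beyond the scatter remains open.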